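A few compounds are considered here, and "the series" means these few. Any claim that something is new, unique, unknown or untested is made for them only; others in the source may bear on it.

Among the compounds with values here, compound 1, `Cc1cnc2nc(-c3ccc4ccccc4c3)cc(O)c2c1`, is the only compound here with a number in a functional assay on OVCAR-3 cells (Homo sapiens) for antiproliferative activity (on this read-out higher numbers stand for weaker inhibition of growth and lower numbers for stronger inhibition of growth), where compound 1 gives 355 nM. Compound 2, `Cc1ccnc2nc(-c3cccc4ccccc34)cc(O)c12`, gives in this assay only < 10 nM, which is a limit of the assay and not a number; this is the limit of < 10 nM in this assay, at which 1 of the 2 values shown sits. Compound 3, `Oc1cc(-c2ccc3ccccc3c2)nc2ncccc12`, has not yet been measured. It differs from compound 1 by hydrogen in place of methyl on an aromatic carbon. Within the data shown here, no measured pair shows this change. The step from compound 1 to compound 3 in this assay is expected to be small, a modest weakening at most, close to the usual scatter. For compound 3 the estimate is 600 nM, between 200 nM and 2000 nM, which is expected to mean a step of a 1.7-fold higher number from compound 1 to compound 3 (0.23 log units; within the scatter).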

Compound 3, concentration for 50% growth inhibition: 8320 nM
For compound 3 the middle estimate is 14-fold (1.14 log units) below the measured one; measured number above the stated range.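

Hydrogen in place of methyl on this aromatic carbon, two atoms from the ring nitrogen, gives a 23-fold higher number from compound 1 to compound 3 (1.37 log units; beyond the scatter) in this assay. Within the data shown here, a change of a single carbon atom at this position is therefore enough to weaken growth inhibition far beyond the scatter, which no earlier measured pair could show. Only methyl and hydrogen are shown at this position, so it stays open whether a longer chain such as ethyl, a methoxy group or an amine would restore or further weaken the inhibition of growth. Nothing shown here accounts for the size of this step.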